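Notes on the step to compound 4

The compounds below may be only part of what the source reports. "The series", "measured", "known", "first", "only" and "open" are said of these compounds alone.

In a functional assay on Rec1 cells (Homo sapiens) for inhibition, read by luminescence and CellTiter-Glo, with a stated time of 72 h (a lower number here means a stronger inhibitor, a higher number a weaker inhibitor), compound 1 `C=CC(=O)Nc1ccc(Cn2nc(-c3ccc(Oc4ccccc4)cc3)cc2C(=O)O)cc1` gives > 60000 nM, which is a limit of the assay. Compound 2 `C/C=C/C(=O)Nc1ccc(Cn2nc(-c3ccc(Oc4ccccc4)cc3)cc2C(=O)O)cc1` gives 23600 nM. Compound 3 `CCOC(=O)c1cc(-c2ccc(Oc3ccccc3)cc2)nn1Cc1cccc(NC(=O)CCl)c1` gives 400 nM, the lowest number in the set. Compound 4 `C=CC(=O)Nc1ccc(Cn2nc(-c3ccc(Oc4ccccc4)cc3)cc2C(=O)OCC)cc1` differs from compound 3 as follows: 4-((vinylcarbonyl)amino)phenyl in place of 3-(((chloromethyl)carbonyl)amino)phenyl on a saturated chain carbon bound to an aromatic nitrogen. Going by the values given here, the only measured step bearing on this change is an at least 2.5-fold lower number from compound 1 to compound 2 (0.40 log units; beyond the scatter), where prop-1-en-1-yl replaces the vinyl group that compound 4 carries. Among the compounds with values here, no measured step isolates the exchange itself, so the direction rests on that one step. A higher number is expected in this assay, with an estimated 3.8-fold higher number from compound 3 to compound 4 (0.57 log units; beyond the scatter). Compound 4 is estimated at 1500 nM, with an expected range of 300 nM to 8000 nM.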

Compound 4, half-maximal inhibitory concentration: 2800 nM
The estimate for compound 4 lay 1.9-fold (0.27 log units) below the measured number; low and high end bracket the measured number.
By their numbers in this assay, from the lowest: compound 3; then compound 4; then compound 2. At a limit, above all of these: compound 1.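

In this assay, the exchange now has a measured size: a 7.0-fold higher number from compound 3 to compound 4 (0.85 log units; beyond the scatter), with vinylcarbonyl replacing chloromethylcarbonyl and the 4-amino placing replacing the 3-amino placing in a single step. The ethyl group on the carboxyl oxygen also gets its first reading: an at least 21-fold lower number from compound 1 to compound 4 (1.33 log units; beyond the scatter). Compound 1 gives > 60000 nM, which is a limit of the assay.

Which of the two changes on the phenyl carries the step stays open, since the compounds shown do not separate them. Equally open, going by these compounds, is how a primary amide or a longer ester chain would read in place of the ethyl ester.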